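This account rests on a few compounds, and the source may have more. Where it says the series, first, only, none or still open, it means among the compounds named here.

Of the compounds shown here, three have been measured so far in an ADME assay on Vero cells (Chlorocebus sabaeus) for cytotoxicity, read by resazurin assay, with a stated time of 72 h (a lower number here means that less compound is needed, a higher number that more compound is needed for the effect), and all three return only a limit. Compound 1 `N#C[Se]CC1Cc2ccc(Oc3ccccc3)cc2O1` gives > 20 uM as a limit of the assay, not a number. Compound 2 `N#C[Se]C[C@@H]1Cc2ccc(Oc3ccccc3)cc2O1` gives > 20 uM as a limit too. Compound 3 `FC(F)(F)[Se]CCOc1ccc(Oc2ccccc2)cc1` likewise gives > 20 uM as a limit, so it has no exact place on the scale. The whole set comes down to the limit of > 20 uM in this assay, at which 3 of the 3 values shown sit, and offers no ranking.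

Compound 4 `N#CCCCOc1ccc(Oc2ccccc2)cc1` has not yet been measured. Its change from compound 3 is a group of 3 heavy atoms (2 carbon, 1 nitrogen; no ring) in place of a group of 5 heavy atoms (1 carbon, 3 fluorine, 1 selenium; no ring), on a saturated chain carbon, two bonds along the chain from an oxygen on an aromatic ring and amounts to cyanomethyl entering where the group holding selenium and fluorine leaves.

For the measured compounds named here, the only measured step is a step that the two limits leave unreadable from compound 1 to compound 2 and it has no size to carry over. It also concerns the fact that one of compounds 1 and 2 is drawn with a defined configuration and the other without, at the place where they differ and not an exchange of groups like this one. No step beyond the scatter can therefore be argued in this assay in either direction, and compound 4 is expected to stay in the same region as the others. The estimated step is a step that the limit leaves unreadable from compound 3 to compound 4 and it should be read with caution, since it starts from a limit. Compound 4 is estimated at 30 uM with an expected range from 15 uM to 80 uM and will probably be reported as a limit as well.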

Compound 4, concentration for half-maximal effect: > 20 uM
Compound 4: a limit, no number (the forecaster's own chance of this, stated with the estimate: 80%); the middle value is on the limit's open side.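

No step can be read between compound 3 and compound 4, since each gives only a limit in this assay and not a number: the limit of > 20 uM in this assay, at which 4 of the 4 values shown sit.

The compounds shown leave open where any of them would fall on the scale of this assay, and whether cyanomethyl in place of the group holding selenium and fluorine changes the read-out at all.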